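Fluoro in place of bromo on compound 2

The compounds below may be only part of what the source reports. "The series", "measured", "known", "first", "only" and "open" are said of these compounds alone.

Values in a functional assay on NCI-H460 cells (Homo sapiens) for inhibition, read by MTT assay, with a stated time of 72 h (a lower number here means a stronger inhibitor, a higher number a weaker inhibitor), for the measured compounds:
compound 1 `COc1cc(NC(C)CCCNC(=O)Nc2cccc(F)c2)c2ncccc2c1` at 24000 nM
compound 2 `COc1cc(NC(C)CCCNC(=O)Nc2ccc(Br)cc2)c2ncccc2c1` at 30000 nM
compound 3 `COc1cc(NC(C)CCCNC(=O)NNC(=O)Nc2ccc(C(F)(F)F)cc2)c2ncccc2c1` at 12000 nM

Compound 2 and compound 1 lie within the scatter of each other, and only compound 3 reads a lower number than compound 2 by more than the scatter. Compound 4 `COc1cc(NC(C)CCCNC(=O)Nc2ccc(F)cc2)c2ncccc2c1` has not yet been measured. It differs from compound 2 in one place (fluoro in place of bromo on an aromatic carbon), with fluoro in place of bromo on an aromatic carbon, para to a large group.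

For the measured compounds named here, one measured step bears on this change. It is a 1.3-fold higher number from compound 1 to compound 2 (0.10 log units; within the scatter) and it stays within the scatter, although the fluoro of compound 1 also sits at a different place on the ring. Going by the values given here, no measured pair exchanges the two groups at the same place. A step beyond the scatter is therefore not expected in this assay in either direction. The estimate amounts to a 1.2-fold lower number from compound 2 to compound 4 (0.08 log units; within the scatter) as the expected change. The estimated value for compound 4 is 25000 nM with an expected range from 14000 nM to 45000 nM in this measurement.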

Compound 4, half-maximal inhibitory concentration: 26000 nM
For compound 4 the middle estimate is 1.0-fold (0.02 log units) below the measured one, and the stated range covers the measured number.
By their numbers in this assay, from the lowest: compounds 3, 1, 4 and 2 (each within the scatter of the next, the first and the last beyond it).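

With bromo and fluoro now exchanged at the same place on the ring in this assay, the direct reading is a 1.2-fold lower number from compound 2 to compound 4 (0.06 log units; within the scatter), which stays within the scatter, whereas the earlier step also moved the halogen. The new pair with the same fluoro at two places gives a 1.1-fold higher number from compound 1 to compound 4 (0.03 log units; within the scatter), also within the scatter, so among compounds 1, 2 and 4 neither this exchange nor this shift of fluoro separates the values. No measurement shown here offers an explanation for these small steps.

Still open, as far as these compounds go, is whether a different kind of group on this aromatic carbon, such as an amine or a carboxylic acid, would produce a step beyond the scatter. Compound 3 differs from these compounds in more than one place, so the contribution of its trifluoromethyl group and of its longer linking chain cannot be separated.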